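The compounds below may be only part of what the source reports. "The series", "measured", "known", "first", "only" and "open" are said of these compounds alone.

Measured in a functional assay on KYSE-410 cells (Homo sapiens) for antiproliferative activity, read by MTT assay, with a stated time of 72 h; a higher number here means a weaker inhibitor, a lower number a stronger inhibitor:
Compound 1 `O=C(Nc1ccc(Cl)cc1)c1cc(=O)[nH]c2cc(Br)ccc12`: > 20000 nM, a limit of the assay
Compound 2 `O=C(Nc1ccccn1)c1cc(=O)[nH]c2cc(Br)ccc12`: 9800 nM
Compound 3 `O=C(Nc1cccc(F)c1)c1cc(=O)[nH]c2cc(Br)ccc12`: 7300 nM

Compound 3 cannot be separated from compound 2, with a 1.3-fold lower number from compound 2 to compound 3 (0.13 log units; within the scatter). Compound 4 `O=C(Nc1cccc(OC(F)(F)F)c1)c1cc(=O)[nH]c2cc(Br)ccc12` carries trifluoromethoxy in place of fluoro on an aromatic carbon, meta to a large group (trifluoromethoxy in place of fluoro on an aromatic carbon). For the measured compounds named here, two measured steps bear on this only loosely, since each swaps the whole group on the amide-type nitrogen: an at least 2.7-fold lower number from compound 1 to compound 3 (0.43 log units; beyond the scatter), and an at least 2.0-fold lower number from compound 1 to compound 2 (0.30 log units; that floor lies within the scatter). Neither shows what this exchange alone does in this assay. The expected step is a 1.2-fold lower number from compound 3 to compound 4 (0.09 log units; within the scatter), with no move beyond the scatter foreseen. For compound 4 the estimated value is 6000 nM, within an expected range of 2200 nM to 16000 nM.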

Compound 4, half-maximal inhibitory concentration: 14000 nM
Estimate against measurement, compound 4: 2.3-fold (0.37 log units) below; the measured number falls inside the stated range.
By their numbers in this assay, from the lowest: compounds 3, 2 and 4 (each within the scatter of the next). At a limit, above all of these: compound 1.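

In this assay, the exchange of fluoro for trifluoromethoxy on an aromatic carbon, meta to a large group, gives a 1.9-fold higher number from compound 3 to compound 4 (0.28 log units; within the scatter). Unlike the earlier steps, which swapped the whole group on the amide-type nitrogen, this one shows that going from one heavy atom to five at this place, with a hydrogen-bond acceptor added, produces no separable change. Compound 1 remains the only compound at a limit of the assay, which is not a number: the limit of > 20000 nM in this assay, at which 1 of the 4 values shown sits.

From the compounds shown here alone, whether an amine, a carboxylic acid or a longer chain at this place would move the number beyond the scatter stays open. So does whether the same exchange would behave alike elsewhere on the aromatic ring.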